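This account rests on a few compounds, and the source may have more. Where it says the series, first, only, none or still open, it means among the compounds named here.

Measured compounds in the series:

Compound 1 `COc1cc(/C=C/C(=O)c2cccc(NC(=O)c3cc(Cl)cc(Cl)c3)c2)ccc1O`; in a functional assay on Vero cells (Chlorocebus sabaeus) for inhibition (on this read-out lower numbers stand for stronger inhibition and higher numbers for weaker inhibition), compound 1 reaches only a limit, > 50 ug/mL.
Compound 2 `COc1cc(/C=C/C(=O)c2cccc(NC(=O)c3ccco3)c2)ccc1O`; in this assay compound 2 gives 3.11 ug/mL.

Compound 1 stands at the limit of the read-out, so its position on the scale is known only as a bound (the limit of > 50 ug/mL in this assay, at which 1 of the 2 values shown sits). Within the data shown here, the one measured step within this pair is an at least 16-fold lower number from compound 1 to compound 2 (1.20 log units; beyond the scatter), which shows that removing the 3,5-dichlorophenyl from the carbonyl carbon is compatible with a much lower number.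

Compound 3 `CCOC(=O)C(=O)Nc1cccc(C(=O)/C=C/c2ccc(O)c(OC)c2)c1` is the next analogue, differing from compound 1 by ethoxycarbonyl in place of 3,5-dichlorophenyl on a carbonyl carbon. Among the measured compounds shown here, only the step to compound 2 bears on it, and that step concerns a different incoming group, so its size gives a direction rather than a magnitude. Given the large lowering seen in an at least 16-fold lower number from compound 1 to compound 2 (1.20 log units; beyond the scatter), a lower number than the limit of compound 1 is expected in this assay, though a weaker gain than with compound 2 is allowed for, since no ring enters. The expected step is an at least 4.1-fold lower number from compound 1 to compound 3 (0.61 log units; beyond the scatter). Compound 3 is estimated at 12 ug/mL, with a range from 3 ug/mL to 50 ug/mL.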

Compound 3, half-maximal inhibitory concentration: > 50 ug/mL
Compound 3: only a limit was reported; the forecaster's own chance of this, stated with the estimate: 35%; at least 4.1-fold (0.61 log units) between middle value and limit.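

In this assay the low number of compound 2 does not carry over to ethoxycarbonyl on this carbonyl carbon, with an at least 16-fold higher number from compound 2 to compound 3 (1.20 log units; beyond the scatter). Losing the 3,5-dichlorophenyl is therefore not enough by itself, and among the three groups shown on this carbon, only furan-2-yl gives a value that is a number rather than a limit. Compound 1 and compound 3 both stand at a limit, and the step between them cannot be read: the limit of > 50 ug/mL in this assay, at which 2 of the 3 values shown sit.

It remains open what in furan-2-yl goes with the lower number, as the compounds shown do not separate the presence of a ring from the ring oxygen, and thiophen-2-yl or unsubstituted phenyl on the same carbonyl carbon would bear on that. As far as these compounds go, it is also open how far compound 1 and compound 3 lie past the limit, so no order between them can be given, and a short alkyl amine in place of ethoxycarbonyl would show whether any group without a ring can reach a measurable value here.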